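A Trimethoxyanilino Pyrimidine Loses Its Aryl Ether

The source may report more compounds than this note shows. Statements on the series, on what has been measured and on what is new or still open speak of the compounds shown alone.

Two measured compounds frame this small set. Compound 1 `Cc1cccc(Nc2ncc(Br)c(Oc3cc(Cl)cc(Cl)c3)n2)c1` reaches only a limit in a functional assay on U-937 cells (Homo sapiens) for antiproliferative activity, read by MTT assay, with a stated time of 24 h (on this read-out lower numbers stand for stronger inhibition and higher numbers for weaker inhibition), where compound 1 gives > 50000 nM. Within the data shown here, compound 2 `COc1cc(Nc2ncc(Br)c(Oc3ccc([N+](=O)[O-])cc3F)n2)cc(OC)c1OC` is the one compound with an actual number in this assay, and compound 2 gives 12900 nM. The remaining value in the set sits at the assay ceiling (the limit of > 50000 nM in this assay, at which 1 of the 2 values shown sits).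

Compound 3 `COc1cc(Nc2ncc(Br)c(ONCCCN)n2)cc(OC)c1OC` has not yet been measured. It differs from compound 2 in a single place: (3-aminopropyl)amino in place of 2-fluoro-4-nitrophenyl on an oxygen on an aromatic ring. Among the measured compounds shown here, no measured pair in the set shows a change of this kind, so the size of the step cannot be read from existing data, only expected. Since the group that leaves carries a ring and the group that enters carries none, the author expects a step from compound 2 to compound 3 of a 2.2-fold higher number from compound 2 to compound 3 (0.34 log units; beyond the scatter), toward weaker inhibition in this assay and beyond the usual scatter. Compound 3 is accordingly estimated at 28000 nM, within a range from 9000 nM to 90000 nM.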

Compound 3, half-maximal inhibitory concentration: 20700 nM
Compound 3: the middle estimate sits 1.4-fold (0.13 log units) above what was measured, within the range that was stated.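

In this assay, the exchange on an oxygen on an aromatic ring gives a 1.6-fold higher number from compound 2 to compound 3 (0.21 log units; within the scatter). Compound 2 and compound 3 therefore cannot be told apart on this read-out, even though the ringless (3-aminopropyl)amino takes the place of 2-fluoro-4-nitrophenyl, so in this pair the six-membered aromatic ring at this place is not needed to keep the value within the scatter. Nothing measured in this set offers a reason for that outcome.

On these data alone, whether a longer chain, or a carboxylic acid in place of the amine of the chain, would also stay within the scatter of compound 3 remains open. Among these compounds, compound 1 stands at a limit and differs from the other compounds in more than one place, so no step to it can be read.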